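The source may hold more compounds than are shown below. What is called first, only, known or untested is meant among the compounds shown, and "the series" means these compounds.

Of the compounds shown here, three with a shared core have been measured in a functional assay on SK-OV-3 cells (Homo sapiens) for antiproliferative activity, read by MTT assay, with a stated time of 72 h; on this read-out higher numbers stand for weaker inhibition and lower numbers for stronger inhibition. Compound 1 `C#Cc1ccc(NC(=O)CCc2cccc3c2B(O)OC3)cc1` gives 6300 nM, compound 2 `CC(C)(C)c1ccc(NC(=O)CCc2cccc3c2B(O)OC3)cc1` gives 4200 nM, and compound 3 `C#Cc1cccc(NC(=O)CCc2cccc3c2B(O)OC3)c1` gives 980 nM. On these numbers compound 3 stands lowest of the three, and its gaps to compound 2 and to compound 1 both lie beyond the usual scatter, so it is the strongest inhibitor shown.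

Compound 4 `CSc1cccc(-c2cccc(NC(=O)CCc3cccc4c3B(O)OC4)c2)c1` differs from compound 3 in one place: 3-(methylsulfanyl)phenyl in place of ethynyl on an aromatic carbon. The new group is a six-membered aromatic ring of carbon only bearing a methylsulfanyl group, and it sits meta to a large group.

Among the measured compounds shown here, only one measured step bears on this change. The step of a 1.5-fold lower number from compound 1 to compound 2 (0.18 log units; within the scatter) swaps one group for another on an aromatic carbon and stays within the scatter, which suggests that replacing the ethynyl group does not by itself move the number much. For the measured compounds named here, no measured pair, however, adds a ring in place of a two-atom chain, so the step to compound 4 is largely unprecedented here.

Compound 4 is therefore expected to show a 1.1-fold higher number from compound 3 to compound 4 (0.05 log units; within the scatter), with the estimate for compound 4 in this assay at 1100 nM, and a range from 300 nM to 4500 nM.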

Compound 4, half-maximal inhibitory concentration: 150 nM
Beside the measured number, compound 4's estimate is 7.3-fold (0.87 log units) above it; measured number below the stated range.
By their numbers in this assay, from the lowest: compound 4; then compound 3; then compounds 2 and 1 (each within the scatter of the next).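

In this assay, putting 3-(methylsulfanyl)phenyl in place of ethynyl on this aromatic carbon gives a 6.5-fold lower number from compound 3 to compound 4 (0.82 log units; beyond the scatter) and shows that this position can carry a group with a six-membered aromatic ring and 8 heavy atoms without losing activity; until now, only the 2-carbon ethynyl group had been seen there. Among the compounds shown here, the one earlier step, a 1.5-fold lower number from compound 1 to compound 2 (0.18 log units; within the scatter), stayed within the scatter, whereas this step lies beyond it, so a change of group on an aromatic carbon of this series can clearly shift the number. Nothing shown here explains the drop, so it cannot be said whether the ring, the methylsulfanyl group or both account for it.

The compounds shown leave open whether an unsubstituted phenyl ring would give a similar number, or whether a methoxy group or an amine could take the place of the methylsulfanyl group on the new ring. They also leave open what 3-(methylsulfanyl)phenyl would do on the aromatic carbon that carries ethynyl in compound 1.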